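Notes on the cyclopropyl to 4-fluorophenyl exchange

The source may hold more compounds than are shown below. What is called first, only, known or untested is meant among the compounds shown, and "the series" means these compounds.

Measured compounds in an ADME assay on microsomes from liver (Rattus norvegicus), read by LC-MS, using NADPH, with a stated time of 30 min, tested at 1 uM; on this read-out lower numbers stand for a less stable compound and higher numbers for a more stable compound:
Compound 1 `C[C@H](Nc1ncnc(N)c1C#N)c1cc(=O)n2cc(F)ccc2c1-c1cc(F)cc(F)c1` gives 60%.
Compound 2 `Cc1c([C@H](C)Nc2nc(N)nc(N)c2C#N)c(-c2ccccc2)c(=O)n2cc(F)ccc12` gives 85%.
Compound 3 `C[C@H](Nc1nc(N)nc(N)c1C#N)c1c(-c2ccccc2)c(=O)n2cc(F)ccc2c1C1CC1` gives 84%.

Compound 3 stands second highest of the three numbers in this assay; compound 2 is its nearest neighbour, within the scatter, and compound 1 is furthest from it, below and beyond the scatter. Compound 4 `C[C@H](Nc1nc(N)nc(N)c1C#N)c1c(-c2ccccc2)c(=O)n2cc(F)ccc2c1-c1ccc(F)cc1` differs from compound 3 by 4-fluorophenyl in place of cyclopropyl on an aromatic carbon. Among the measured compounds shown here, only one measured step touches this position: a number 1 percentage points lower from compound 2 to compound 3 (within the scatter), in which a methyl was exchanged for the cyclopropyl that now leaves, and that step was within the scatter. For the measured compounds named here, no measured step exchanges a cyclopropyl for an aromatic ring, so the present step has no direct precedent, and a larger move than the one seen cannot be ruled out. For compound 4 the expected value in this assay is 70%, with a range from 50% to 88%. The expected step is estimated as a number 14 percentage points lower from compound 3 to compound 4 (beyond the scatter), a modest fall that may still lie within the scatter.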

Compound 4, percent of the compound remaining: 77%
The estimate for compound 4 lay 7 percentage points below the measured number, within the range that was stated.
By their numbers in this assay, from the lowest: compound 1; then compounds 4, 3 and 2 (each within the scatter of the next).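

In this assay, this position accepts an aromatic ring as well as the smaller carbon groups: 4-fluorophenyl in place of cyclopropyl gives a number 7 percentage points lower from compound 3 to compound 4 (within the scatter), and 4-fluorophenyl in place of methyl gives a number 8 percentage points lower from compound 2 to compound 4 (within the scatter). The read-out therefore does not separate methyl, cyclopropyl and 4-fluorophenyl here, even though the exchange from cyclopropyl to 4-fluorophenyl goes from 3 heavy atoms to 7 heavy atoms and from a non-aromatic ring to an aromatic one. No supporting data are available to explain this result.

From the compounds shown here alone, whether an amine, a carboxylic acid or a longer chain at this position would also stay within the scatter remains open. Also open, going by these compounds, is whether 4-fluorophenyl would behave the same way on the core of compound 1, which differs from these compounds in more than one place.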